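The compounds below may be only part of what the source reports. "The series", "measured", "known", "first", "only" and "open" are said of these compounds alone.

Among the compounds with values here, in a functional assay on the whole organism (strain albino) with Mus musculus as the target, with a stated time of 0.5 h (a higher number here means that more compound is needed for the effect, a lower number that less compound is needed), compound 1 `CC(=O)N1N=C(Nc2nc3ccc(C)cc3s2)CC1c1ccc(O)cc1` comes in at 54.3 umol/kg and is the only compound with a number so far. Compound 2 `CC(=O)N1N=C(Nc2nc3ccc([N+](=O)[O-])cc3s2)CC1c1ccc(O)cc1` has the entry "not determined" (no result reported) in this assay and so offers no comparison. That leaves compound 1 with nothing to be ranked against, and whether its dose counts as low or high cannot be told from these data.

Compound 3 `CC(=O)N1N=C(Nc2nc3ccc(C)cc3s2)CC1c1ccc(Cl)cc1` keeps the core of compound 1 and changes one thing: chloro in place of hydroxy on an aromatic carbon, para to a large group, so that 4-hydroxyphenyl becomes 4-chlorophenyl (chloro in place of hydroxy on an aromatic carbon). Within the data shown here, no measured pair here shows what a single change does in this assay, so neither the size nor the direction of this step can be read from earlier results. The plainest expectation is therefore no step beyond the usual scatter, while a real move either way remains possible. The estimated step of a 1.0-fold higher number from compound 1 to compound 3 (0.01 log units; within the scatter) is expected to stay small and has no firm direction. Compound 3 is expected at 55 umol/kg with an estimated range of 20 umol/kg to 150 umol/kg as the likely span.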

Compound 3, dose for half-maximal effect: 27.5 umol/kg
Compound 3: middle estimate off by 2.0-fold (0.30 log units), on the high side; low and high end bracket the measured number.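

Within the data shown here, replacing 4-hydroxyphenyl with 4-chlorophenyl gives the first step that can be read in this assay, a 2.0-fold lower number from compound 1 to compound 3 (0.30 log units; within the scatter), so this pair shows no change that stands clear of the usual scatter. At this position on the aromatic ring, chloro, with 0 hydrogen-bond donors and 0 hydrogen-bond acceptors, can therefore take the place of hydroxy, with 1 of each, without a clear shift in the dose needed, at least for this single pair with the shared core of compound 1. No measurement available here explains this outcome.

This is one pair and one swap, so it cannot be told whether other groups at the same position, such as an amine, a carboxylic acid or a methoxy group, would also stay within the scatter or would move the dose clearly in either direction. From the compounds shown here alone, compound 2 has no number, so the step from methyl to nitro on the core cannot be read, and what changes at that other place do in this whole-animal test remains unknown.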